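Aryl swap on the thiazolidine carboxamide series: compound 3

The source may hold more compounds than are shown below. What is called first, only, known or untested is meant among the compounds shown, and "the series" means these compounds.

Two members of the series have been run in a functional assay on DU-145 cells (Homo sapiens) for antiproliferative activity, read by sulforhodamine B assay; on this read-out lower numbers stand for stronger inhibition and higher numbers for weaker inhibition. Compound 1 `CCCCCCCCCCCCCCCCCCNC(=O)[C@H]1CSC(c2ccc(N(C)C)cc2)N1` carries a 4-(dimethylamino)phenyl group and in this assay compound 1 gives 5300 nM. Compound 2 `CCCCCCCCCCCCCCCCCCNC(=O)[C@H]1CSC(c2cccc(O)c2)N1` carries a 3-hydroxyphenyl group in the same place and in this assay compound 2 gives 5700 nM. Compound 2 stands alongside compound 1 rather than apart from it: the step of a 1.1-fold higher number from compound 1 to compound 2 (0.03 log units; within the scatter) is inside the scatter, so the two aryl groups tried so far cannot be told apart on this read-out.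

Compound 3 `CCCCCCCCCCCCCCCCCCNC(=O)[C@H]1CSC(c2ccc(F)c(Br)c2)N1` is the next variation at the same saturated ring carbon: 3-bromo-4-fluorophenyl in place of 3-hydroxyphenyl on a saturated ring carbon. Within the data shown here, the only measured step that touches this position is a 1.1-fold higher number from compound 1 to compound 2 (0.03 log units; within the scatter), and it showed that a substantial change of aryl group left the number where it was. On that basis no movement beyond the scatter is expected for compound 3, and a step of a 1.1-fold lower number from compound 2 to compound 3 (0.06 log units; within the scatter) is the estimate. For compound 3 in this assay the expected value is 5000 nM, with a range from 2000 nM to 12000 nM.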

Compound 3, half-maximal inhibitory concentration: 11300 nM
Estimate against measurement, compound 3: 2.3-fold (0.35 log units) below; the measured number falls inside the stated range.
By their numbers in this assay, from the lowest: compounds 1, 2 and 3 (each within the scatter of the next, the first and the last beyond it).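

In this assay, among these compounds, the step of a 2.1-fold higher number from compound 1 to compound 3 (0.33 log units; beyond the scatter) is the first at this position to clear the scatter, so the aryl group on the saturated ring carbon is not wholly silent, although the effect seen so far is modest and runs towards weaker inhibition. The step of a 2.0-fold higher number from compound 2 to compound 3 (0.30 log units; within the scatter) stays inside the scatter, so compound 2 cannot be separated from compound 3 any more than from compound 1, and the three aryl groups do not fall into two clear sets: only the two ends of the series, compound 1 and compound 3, can be told apart. No measurement on hand bears on why 3-bromo-4-fluorophenyl and 4-(dimethylamino)phenyl differ on this read-out.

Bromine and fluorine enter together in compound 3, so the compounds shown do not tell whether either halogen alone would give the same number, or whether the unsubstituted phenyl group would sit with compound 1 or with compound 3. Also open, going by these compounds, is how a carboxylic acid or a primary amine on the aryl ring would read at this position.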